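The compounds below may be only part of what the source reports. "The series", "measured", "known", "first", "only" and "open" are said of these compounds alone.

Measured in a functional assay on RKO cells (Homo sapiens) for cytotoxicity, read by resazurin assay, with a stated time of 72 h; a higher number here means a weaker inhibitor, a lower number a stronger inhibitor:
compound 1 `Cc1nc2ccccc2n1-c1csc(Nc2cccc(Br)c2)n1`: 36000 nM
compound 2 `Brc1ccc(Nc2nc(-n3cnc4ccccc43)cs2)cc1`: > 100000 nM
compound 3 `Cc1nc2ccccc2n1-c1csc(Nc2ccc(Br)cc2)n1`: 90 nM

The entry for compound 2 is a limit of the assay, not a number. Compound 3 has the lowest number of the set at 90 nM.

Compound 4 `COc1ccc(Nc2nc(-n3c(C)nc4ccccc43)cs2)cc1` is the next case, with methoxy in place of bromo on an aromatic carbon. The closest evidence is a 400-fold lower number from compound 1 to compound 3 (2.60 log units; beyond the scatter), a large step that also changes the 4-bromophenyl group, but by moving the bromo, not replacing it. The other measured step, an at least 1100-fold lower number from compound 2 to compound 3 (3.04 log units; beyond the scatter), is also large but concerns a methyl group elsewhere. Neither tests this replacement, so the size of the change remains uncertain. Compound 4 keeps its substituent para to a large group, as compound 3 does, so a much smaller shift than either measured step is expected. The expected step in this assay is a 3.3-fold higher number from compound 3 to compound 4 (0.52 log units; beyond the scatter), towards a higher number. For compound 4 the estimated value is 300 nM, with an expected range of 40 nM to 5000 nM.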

Compound 4, half-maximal inhibitory concentration: 25 nM
Beside the measured number, compound 4's estimate is 12-fold (1.08 log units) above it; the whole stated range lies above it.
By their numbers in this assay, from the lowest: compound 4; then compound 3; then compound 1. At a limit, above all of these: compound 2.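

In this assay, a bromo group is not needed for a low number at this place, para to a large group: methoxy in place of bromo gives a 3.6-fold lower number from compound 3 to compound 4 (0.56 log units; beyond the scatter) and so extends the series with a second substituent that works here. Set against the 3-bromophenyl group, the 4-methoxyphenyl group gives a 1400-fold lower number from compound 1 to compound 4 (3.16 log units; beyond the scatter) and is the largest listed step between two measured numbers, although that step changes both the substituent and its place on the ring. Nothing measured here accounts for the difference between bromo and methoxy.

From the compounds shown here alone, whether an amine, a carboxylic acid or a longer chain such as ethoxy keeps the number this low at the same place remains open. Also open, going by these compounds, is whether a 3-methoxyphenyl group would match the 4-methoxyphenyl group or fall away as the 3-bromophenyl group does.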